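Halogen removal in the thiazolyl-imine isatin series

The source may hold more compounds than are shown below. What is called first, only, known or untested is meant among the compounds shown, and "the series" means these compounds.

Measured compounds:
- compound 1 `O=C1C(=O)N(CN(c2ccccc2)c2ccccc2)c2cccc(Cl)c21`, a functional assay on MDA-MB-231 cells (Homo sapiens) for cytotoxicity, read by sulforhodamine B assay, with a stated time of 48 h (on this read-out higher numbers stand for weaker inhibition of growth and lower numbers for stronger inhibition of growth), 31400 nM
- compound 2 `Cc1ccc2nc(/N=C3\C(=O)N(CN(c4ccccc4)c4ccccc4)c4cccc(Br)c43)sc2c1`, this assay 75100 nM
- compound 3 `Cc1ccc2nc(/N=C3\C(=O)N(CN(c4ccccc4)c4ccccc4)c4cccc(Cl)c43)sc2c1`, this assay 54000 nM

Compound 3 gives the second highest number of the three; compound 2 and compound 1 sit on either side of it, both within the scatter. The step to compound 4 `Cc1ccc2nc(/N=C3\C(=O)N(CN(c4ccccc4)c4ccccc4)c4ccccc43)sc2c1` is hydrogen in place of chloro on an aromatic carbon. Going by the values given here, the one measured step that bears on it, a 1.4-fold lower number from compound 2 to compound 3 (0.14 log units; within the scatter), exchanged one halogen for another at this position and stayed within the scatter; no measured pair removes the halogen outright, so the direction is not fixed by the data. The change is therefore expected to give a step of about a 1.2-fold lower number from compound 3 to compound 4 (0.08 log units; within the scatter), no larger than the scatter. Compound 4 is estimated at 45000 nM, in a range from 20000 nM to 110000 nM.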

Compound 4, concentration for 50% growth inhibition: 34100 nM
For compound 4 the middle estimate is 1.3-fold (0.12 log units) above the measured one; the range from low to high includes it.
By their numbers in this assay, from the lowest: compounds 1, 4, 3 and 2 (each within the scatter of the next, the first and the last beyond it).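

In this assay, going by these compounds alone, the halogen is now removed outright at this position, which no earlier pair did. Hydrogen in place of chloro gives a 1.6-fold lower number from compound 3 to compound 4 (0.20 log units; within the scatter), and hydrogen in place of bromo gives a 2.2-fold lower number from compound 2 to compound 4 (0.34 log units; beyond the scatter), so the halogen is not needed here to keep growth inhibition at this level. No evidence on the cause of either step is at hand.

The compounds shown carry only bromo, chloro or hydrogen at this position. From the compounds shown here alone, how an amine, a methoxy group or a carboxylic acid would behave there remains open.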